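The source may hold more compounds than are shown below. What is called first, only, known or untested is meant among the compounds shown, and "the series" means these compounds.

Compound 1 `CC(C)(C)c1ccc(C(=O)N2CCC3(CC2)C(=O)N(CC(=O)N2CCC(CCO)CC2)CN3c2ccccc2)cc1` gives 2600 nM in an assay on HEK293 cells for displacement of a labelled ligand from NPC1-like intracellular cholesterol transporter 1 (Homo sapiens) (on this read-out higher numbers stand for weaker inhibition and lower numbers for stronger inhibition), the lowest number among the three measured compounds. Compound 2 `CC(C)(C)c1ccc(C(=O)N2CCC3(CC2)C(=O)N(CC(=O)N2CCCC(O)C2)CN3c2ccccc2)cc1` gives 12200 nM and compound 3 `CC(C)(C)c1ccc(C(=O)N2CCC3(CC2)C(=O)N(CC(=O)NCCCCNS(C)(=O)=O)CN3c2ccccc2)cc1` gives 4500 nM in this assay; the steps read a 4.7-fold higher number from compound 1 to compound 2 (0.67 log units; beyond the scatter), a 1.7-fold higher number from compound 1 to compound 3 (0.24 log units; within the scatter) and a 2.7-fold lower number from compound 2 to compound 3 (0.43 log units; beyond the scatter). Compound 4 `CC(C)(C)OC(=O)NCC1CCN(C(=O)CN2CN(c3ccccc3)C3(CCN(C(=O)c4ccc(C(C)(C)C)cc4)CC3)C2=O)CC1` differs from compound 1 by (tert-butoxycarbonyl)amino in place of hydroxymethyl on a saturated chain carbon bound to a saturated ring carbon. Both measured steps exchange the whole amide substituent, whereas this change alters only the chain on the saturated ring carbon, so neither step bears closely on it; those exchanges did show that changes in this region stay modest. Compound 4 is therefore expected to stay near compound 1, with a step of a 1.3-fold higher number from compound 1 to compound 4 (0.13 log units; within the scatter) within the scatter. The estimate for compound 4 is 3500 nM, with a range from 1200 nM to 10000 nM.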

Compound 4, half-maximal inhibitory concentration: 4200 nM
Compound 4: middle estimate off by 1.2-fold (0.08 log units), on the low side; the range from low to high includes it.
By their numbers in this assay, from the lowest: compounds 1, 4 and 3 (each within the scatter of the next); then compound 2.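

In this assay, putting (tert-butoxycarbonyl)amino in place of hydroxymethyl on a saturated chain carbon bound to a saturated ring carbon gives a 1.6-fold higher number from compound 1 to compound 4 (0.21 log units; within the scatter). At this position, then, the hydroxyl of compound 1 is not needed to hold the read-out, and a substituent of 8 heavy atoms in place of 2 leaves no difference beyond the scatter. No measurement offered here explains this tolerance. On these data alone, both groups carry one hydrogen-bond donor, so the effect of removing that donor stays open. So does whether a free primary amine or a carboxylic acid on this chain would behave the same way.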